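The source may report more compounds than this note shows. Statements on the series, on what has been measured and on what is new or still open speak of the compounds shown alone.

In an assay on isolated protein for inhibition of Nitric oxide synthase, inducible (Homo sapiens), read by scintillation counting, with a stated time of 30 min, tested at 50 uM (on this read-out higher numbers stand for more inhibition at the one concentration tested (going by the name of the read-out) and lower numbers for less inhibition), compound 1 `CC1(C)SC(c2ccccc2N)=NN1C(=O)c1ccccc1` gives 39.8%, and compound 2 `CC(=O)N1N=C(c2ccccc2N)SC1(C)C` gives 22.9%. Among the compounds with values here, compound 2 holds the lowest of the two numbers, and the single measured step, a number 16.9 percentage points lower from compound 1 to compound 2 (beyond the scatter), is the only guide for changes at the carbonyl carbon of the shared core. Compound 3 `CCC(=O)N1N=C(c2ccccc2N)SC1(C)C` is the next member: methyl in place of hydrogen on a saturated chain carbon bound to a carbonyl carbon. Within the data shown here, the one step on record concerns the same carbonyl substituent, but it is a far larger exchange; its size was only modest, and the present change is smaller still, so on this assay no step beyond the scatter is expected, with perhaps a slight lean upward given that compound 1 gave 39.8%. Compound 3 is therefore expected to give 27%, in a range of 12% to 42%. The expected step is a number 4.1 percentage points higher from compound 2 to compound 3 (within the scatter), within the scatter.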

Compound 3, a percentage reported as inhibition, at one concentration (the size of the read-out at that concentration, not a potency): 19.2%
For compound 3 the middle estimate is 7.8 percentage points above the measured one; low and high end bracket the measured number.
By their numbers in this assay, from the lowest: compounds 3 and 2 (each within the scatter of the next); then compound 1.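

In this assay the methyl in place of hydrogen on a saturated chain carbon bound to a carbonyl carbon gives a number 3.7 percentage points lower from compound 2 to compound 3 (within the scatter), so going from acetyl to propanoyl does not separate compound 2 from compound 3. Exchanging the phenyl for an ethyl group gives a number 20.6 percentage points lower from compound 1 to compound 3 (beyond the scatter), which puts compound 1 beyond the scatter of both alkyl members and leaves it with the highest number of the three. No supporting measurement bears on why the phenyl compound stands apart.

Open, on these data alone, is whether a longer chain such as butanoyl stays within the scatter of compound 2 and compound 3. Also open, as far as these compounds go, is whether a cyclohexyl or benzyl group on the carbonyl carbon comes close to compound 1, or whether a substituted phenyl goes beyond it.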